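Amide to urea change in a growth-inhibition series

The compounds below may be only part of what the source reports. "The series", "measured", "known", "first", "only" and "open" are said of these compounds alone.

Measured so far:
compound 1 `COc1cc(-c2nn(-c3cccc(NC(=O)c4ccc(Cl)c(C(F)(F)F)c4)c3)cc2-c2ccncc2)ccc1Cl`: > 32500 nM
compound 2 `COc1cc(-c2nn(-c3cccc(NC(=O)c4ccccc4)c3)cc2-c2ccncc2)ccc1Cl`: > 100000 nM

Compound 2 is defined here only by a limit: in a functional assay on SW-620 cells (Homo sapiens) for inhibition, read by sulforhodamine B assay, with a stated time of 48 h (on this read-out lower numbers stand for stronger inhibition of growth and higher numbers for weaker inhibition of growth), compound 2 gives > 100000 nM, which is a limit of the assay and not a number. Compound 1 likewise gives only a limit, > 32500 nM, in this assay. Going by the values given here, the single measured step, a step that the two limits leave unreadable from compound 1 to compound 2, is therefore unreadable, and it is the only step that touches the part of the molecule changed here. The evidence the limit of > 100000 nM in this assay, at which 1 of the 2 values shown sits, and the limit of > 32500 nM in this assay, at which 1 of the 2 values shown sits, adds nothing beyond those two limits.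

Compound 3 `COc1cc(-c2nn(-c3cccc(NC(=O)Nc4ccc(Cl)c(Cl)c4)c3)cc2-c2ccncc2)ccc1Cl` differs from compound 2 by (3,4-dichlorophenyl)amino in place of phenyl on a carbonyl carbon. No measured step bears on this change in a readable way, so its size and direction cannot be anchored on the numbers shown. Compound 3 is estimated at 20000 nM in this assay, with a wide range from 3000 nM to 100000 nM. The step of an at least 5.0-fold lower number from compound 2 to compound 3 (0.69 log units; beyond the scatter) is thus expected only loosely.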

Compound 3, concentration for total growth inhibition: > 50000 nM
Compound 3 was reported as a limit (the forecaster's own chance of this, stated with the estimate: 45%); at least 2.5-fold (0.39 log units) between middle value and limit.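

In this assay compound 3 gives > 50000 nM, which is a limit of the assay and not a number. Going by these compounds alone, compound 1 and compound 2 are also known only by limits, so no step among the three can be read. On these data alone, the size and direction of any effect of (3,4-dichlorophenyl)amino in place of phenyl on a carbonyl carbon remain open.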